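The source may hold more compounds than are shown below. What is called first, only, known or untested is meant among the compounds shown, and "the series" means these compounds.

Among the measured compounds shown here, compound 1, with the structure `Nc1cc(N)c2nc(-c3ccccc3)c(NCc3ccc(Cl)c(Cl)c3)nc2c1`, is the one compound in this set with a definite number. In a functional assay on CCRF-CEM cells (Homo sapiens) for inhibition, read by sulforhodamine B assay, with a stated time of 48 h (on this read-out lower numbers stand for stronger inhibition of growth and higher numbers for weaker inhibition of growth), compound 1 gives 1820 nM, and no other numerical result stands beside it for comparison. Compound 2, with the structure `CCOC(=O)[C@H](CCC(=O)O)NC(=O)c1ccc(Oc2nc3cc(N)cc(N)c3nc2-c2ccccc2)cc1`, is reported only as a limit of this assay, < 100000 nM, and not as a number. That reading is described as the limit of < 100000 nM in this assay, at which 1 of the 2 values shown sits.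

Compound 3, with the structure `COc1ccc(CNc2nc3cc(N)cc(N)c3nc2-c2ccccc2)cc1`, has not yet been tested in this assay. It differs from compound 1 in one place: 4-methoxyphenyl in place of 3,4-dichlorophenyl on a saturated chain carbon bound to a nitrogen on an aromatic ring. For the measured compounds named here, no two measured compounds here differ in only one place, so there is no measured step of this kind to lean on, and the expectation for compound 3 rests on compound 1 alone. The step is expected to be small, somewhat toward weaker inhibition of growth, and the estimate is a 2.2-fold higher number from compound 1 to compound 3 (0.34 log units; beyond the scatter). Compound 3 is therefore expected to give about 4000 nM in this assay, within a range from 1000 nM to 16000 nM.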

Compound 3, concentration for total growth inhibition: 64600 nM
Compound 3: middle estimate off by 16-fold (1.21 log units), on the low side; the whole stated range lies below it.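

At this position, on a saturated chain carbon bound to a nitrogen on an aromatic ring, the choice of aromatic group matters a great deal: in this assay, 4-methoxyphenyl in place of 3,4-dichlorophenyl gives a 35-fold higher number from compound 1 to compound 3 (1.55 log units; beyond the scatter), a large loss of growth inhibition. Among the compounds shown here, the two groups have the same count of heavy atoms and each has one six-membered aromatic ring of carbon only, so a change that leaves those counts alone can still move the result strongly, something the earlier compounds, with no pair differing in one place, could not show. Compound 3 still has a definite number, but the read-out also has an upper limit, which may leave little room to put a number on any further loss in this series: the limit of < 100000 nM in this assay, at which 1 of the 3 values shown sits.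

This single step does not tell whether the loss goes with removing the chlorine atoms or with adding the methoxy group, and a plain phenyl or a 4-chlorophenyl at this place would help to separate the two. Also open, on these data alone, is what a longer chain carrying the same 3,4-dichlorophenyl would do here.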